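A few compounds are considered here, and "the series" means these few. Any claim that something is new, unique, unknown or untested is made for them only; others in the source may bear on it.

Compound 1, `CCc1cc(C(C)=O)c(O)cc1OCCCCC(C)(C)C#N`, gives 5% in an assay on isolated protein for binding affinity to leukotriene B4 receptor (Homo sapiens), tested at 0.1 uM; on this read-out lower numbers stand for less inhibition and higher numbers for more inhibition at the one concentration tested (going by the name of the read-out).
Compound 2, `CCc1cc(C(C)=O)c(O)cc1OCCCCCC(C)(C)C#N`, gives 17%.
Compound 3, `CCc1cc(C(C)=O)c(O)cc1OCCCCCC(C)(C)C(=O)O`, gives 20%.

Compound 3 stands highest of the three numbers; its nearest neighbour is compound 2, with a number 3 percentage points higher from compound 2 to compound 3 (within the scatter), a step within the scatter, while a number 15 percentage points higher from compound 1 to compound 3 (beyond the scatter) lies beyond it. Compound 4, `CCc1cc(C(C)=O)c(O)cc1OCCCC(C)(C)C(N)=O`, awaits measurement in this assay. Its change from compound 3: 1-carbamoyl-1-methylethyl in place of 3-carboxy-3-methylbutyl on a saturated chain carbon, three bonds along the chain from an oxygen on an aromatic ring. Among the measured compounds shown here, no measured step exchanges carboxy for carbamoyl, so only the steps that lengthen the chain bear on it: a number 12 percentage points higher from compound 1 to compound 2 (beyond the scatter) and a number 15 percentage points higher from compound 1 to compound 3 (beyond the scatter), both modest, both upward. Compound 4 carries its group three bonds along the chain from an oxygen on an aromatic ring, fewer than compound 1 does, and a fall is therefore expected, a number 13 percentage points lower from compound 3 to compound 4 (beyond the scatter). The estimate for compound 4 is 7%, ranging from 0% to 18%.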

Compound 4, a percentage reported as inhibition, at one concentration (the size of the read-out at that concentration, not a potency): 16%
Estimate against measurement, compound 4: 9 percentage points below, within the range that was stated.
By their numbers in this assay, from the lowest: compound 1; then compounds 4, 2 and 3 (each within the scatter of the next).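

In this assay a shorter chain did not bring the fall that compound 1 had suggested: compound 4, with 1-carbamoyl-1-methylethyl at this position, shows a number 4 percentage points lower from compound 3 to compound 4 (within the scatter) and a number 1 percentage points lower from compound 2 to compound 4 (within the scatter) while still showing a number 11 percentage points higher from compound 1 to compound 4 (beyond the scatter) as well. Here a group of 6 heavy atoms thus stays level with the groups of 8 heavy atoms in compound 2 and compound 3. Nothing available explains this result. The chain and its end group change together in compound 4, so their shares cannot be separated. As far as these compounds go, how a primary amine or a tetrazole would fare on either chain remains open.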